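A few compounds are considered here, and "the series" means these few. Any claim that something is new, unique, unknown or untested is made for them only; others in the source may bear on it.

In an ADME assay on LLC-MK2 cells (Macaca mulatta) for cytotoxicity, read by spectrophotometry and crystal violet staining, with a stated time of 4 days (a lower number here means that less compound is tolerated, a higher number that more compound is tolerated), compound 1 (`CC(C)n1ncc2c(C(=O)Nc3ccccn3)cc(C3CC3)nc21`) gives 25000 nM as its half-maximal cytotoxic concentration, and compound 2 (`CC(C)n1ncc2c(C(=O)Nc3ccccn3)cc(-c3ccsc3)nc21`) gives 25000 nM on the same read-out, so compound 2 stands level with compound 1. Compound 3 (`CC(C)n1ncc2c(C(=O)Nc3cccnc3)cc(-c3ccsc3)nc21`) carries pyridin-3-yl in place of pyridin-2-yl on an amide-type nitrogen and otherwise matches compound 2. Within the data shown here, only one measured step is available, no change at the digits printed from compound 1 to compound 2 (within the scatter) for thiophen-3-yl in place of cyclopropyl on an aromatic carbon. Among the measured compounds shown here, it lies at another place and so bears on this change only indirectly, and no measured step covers the amide-type nitrogen. Starting from compound 2 at 25000 nM for that reason, no step beyond the scatter is expected in this assay here. The estimate means no change at the digits printed from compound 2 to compound 3 (within the scatter) as the expected move. Compound 3 is estimated at 25000 nM with an expected range from 12500 nM to 50000 nM on this read-out.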

Compound 3, half-maximal cytotoxic concentration: 37000 nM
Compound 3: the middle estimate sits 1.5-fold (0.17 log units) below what was measured; the range from low to high includes it.
By their numbers in this assay, from the lowest: compounds 1, 2 and 3 (each within the scatter of the next).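

The amide-type nitrogen now has a measured step of its own: in this assay pyridin-3-yl in place of pyridin-2-yl gives a 1.5-fold higher number from compound 2 to compound 3 (0.17 log units; within the scatter) and stays within the scatter. Neither change seen so far, on the aromatic carbon or on the amide-type nitrogen, has therefore moved this read-out beyond the scatter, even though this second change only joins the same atoms differently. Nothing available explains this result.

Going by these compounds, it remains open whether a phenyl ring, pyridin-4-yl or a pyridine ring carrying an amine or a carboxylic acid on the amide-type nitrogen would move the number in this assay beyond the scatter. On these data alone, it is also open whether pyridin-3-yl would behave the same way with cyclopropyl in place of thiophen-3-yl on the shared core.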